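One Methyl Group, Two Different Places

A few compounds are considered here, and "the series" means these few. Any claim that something is new, unique, unknown or untested is made for them only; others in the source may bear on it.

Compound 1, `O=C(Nc1ccccc1)c1cc2ccccc2oc1=O`, gives 760 nM in an in vitro assay on BTI-TN-5B1-4 cells for inhibition of Amine oxidase [flavin-containing] B (Homo sapiens), read by fluorescence; a higher number here means a weaker inhibitor, a lower number a stronger inhibitor.
Compound 2, `Cc1cccc(NC(=O)c2cc3ccccc3oc2=O)c1`, gives 600 nM.
Compound 3, `COc1ccc(NC(=O)c2cc3ccc(OCc4ccccc4)cc3oc2=O)cc1OC`, gives 4390 nM.

Compound 4, `COc1ccc(NC(=O)c2cc3ccc(OCc4ccccc4)c(C)c3oc2=O)cc1OC`, has not yet been measured. Compound 2 differs from compound 1 by methyl in place of hydrogen on an aromatic carbon. That change gave a 1.3-fold lower number from compound 1 to compound 2 (0.10 log units; within the scatter). Compound 4 differs from compound 3 by methyl in place of hydrogen on an aromatic carbon, the same kind of change, but the surroundings differ: in compound 2 the methyl sits meta to a large group on a plain six-membered ring, whereas in compound 4 it sits on a ring that is part of a fused system, ortho to a benzyloxy group. The difference between the cores of compound 1 and compound 3 is not broken down here; compound 3 gives the highest number of the three. Because the measured step of a 1.3-fold lower number from compound 1 to compound 2 (0.10 log units; within the scatter) was small, compound 4 is expected to show a similarly small step, a 1.3-fold lower number from compound 3 to compound 4 (0.10 log units; within the scatter). The estimate for compound 4 is 3500 nM, with a range from 1500 nM to 8000 nM.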

Compound 4, half-maximal inhibitory concentration: 4980 nM
The estimate for compound 4 lay 1.4-fold (0.15 log units) below the measured number, within the range that was stated.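

In this assay, the methyl step on the second core stays within the scatter, with a 1.1-fold higher number from compound 3 to compound 4 (0.05 log units; within the scatter). Set beside the earlier step, it agrees with what was seen on the first core: the same change on two cores in this assay, a 1.3-fold lower number (0.10 log units; within the scatter) from compound 1 to compound 2 and a 1.1-fold higher number (0.05 log units; within the scatter) from compound 3 to compound 4, 1.4-fold (0.16 log units) apart, within the scatter of two such steps. In these two pairs, then, the change carries from one core to the other as a step too small to read, but two pairs make no general rule, and they do not show how a methyl would behave elsewhere on these cores.

Going by these compounds, whether an amine, a carboxylic acid or a longer chain in place of this methyl would shift the number remains open. Also open is which of the several differences between compound 1 and compound 3 accounts for the gap between their values.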